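This account rests on a few compounds, and the source may have more. Where it says the series, first, only, none or still open, it means among the compounds named here.

Of the compounds shown here, three with a shared core have been measured in an assay on HepG2 cells for agonist activity at nuclear receptor subfamily 1 group I member 3 (Homo sapiens), read by a luciferase reporter, with a stated time of 23 h; on this read-out lower numbers stand for an effect already at smaller amounts and higher numbers for an effect only at larger amounts of compound. Compound 1 `FC(F)(F)c1ccc(CO/N=C/c2c(-c3ccc4ccccc4c3)nc3occn23)cc1` gives 470 nM. For the measured compounds named here, compound 2 `Clc1ccc(CO/N=C/c2c(-c3ccc4ccccc4c3)nc3occn23)cc1` gives 990 nM; the only change between them is chloro in place of trifluoromethyl on an aromatic carbon, and a 2.1-fold higher number from compound 1 to compound 2 (0.32 log units; beyond the scatter). Compound 3 `Clc1ccc(CO/N=C/c2c(-c3ccc(Br)cc3)nc3sccn23)cc1Cl`, which carries a different core and a bromo group, gives 480 nM. Compared with compound 1 its number differs only within the scatter, while compound 2 sits beyond the scatter at a higher number.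

Compound 4 `Clc1ccc(CO/N=C/c2c(-c3ccccc3)nc3sccn23)cc1Cl` is not yet measured. It differs from compound 3 in one place: hydrogen in place of bromo on an aromatic carbon. Going by the values given here, no measured step matches this change; the single measured step concerns a different group on a different ring and was modest in size. On that basis no shift beyond the scatter in this assay is expected, and the estimate for compound 4 is 650 nM, with a likely range from 250 nM to 1700 nM, meaning an expected step of a 1.4-fold higher number from compound 3 to compound 4 (0.13 log units; within the scatter).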

Compound 4, half-maximal effective concentration: 580 nM
Compound 4: middle estimate off by 1.1-fold (0.05 log units), on the high side, within the range that was stated.
By their numbers in this assay, from the lowest: compounds 1, 3, 4 and 2 (each within the scatter of the next, the first and the last beyond it).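

Going from 4-bromophenyl to phenyl in this assay gives a 1.2-fold higher number from compound 3 to compound 4 (0.08 log units; within the scatter), so compound 3 and compound 4 cannot be told apart on this read-out. For the compounds shown here, this is the first pair to differ at this position, an aromatic carbon para to a large group, and it shows that within this pair the bromo can give way to hydrogen with no change beyond the scatter. No further data accompany this pair to explain the result.

At this position the compounds shown carry only bromo or hydrogen, so it remains open how an amine, a carboxylic acid or a longer chain there would read. Also open, from the compounds shown here alone, is whether the same swap would stay within the scatter on the core of compound 1.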